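Compound 3 to compound 4: pyridin-2-yl for phenyl

The source may hold more compounds than are shown below. What is called first, only, known or untested is meant among the compounds shown, and "the series" means these compounds.

Three compounds have numbers in a functional assay on PC-3 cells (Homo sapiens) for inhibition; a lower number here means a stronger inhibitor, a higher number a weaker inhibitor. Compound 3 `c1ccc(Nc2nc(-c3nc4ccccc4s3)cs2)cc1` gives 5500 nM, the highest of the three. Compound 1 `c1ccc(Nc2cccc(-c3nc4ccccc4s3)c2)nc1` gives 4800 nM, which lies within the scatter of compound 3. Compound 2 `CCn1c(=O)/c(=C2\Sc3ccccc3N2C)s/c1=C\c1ccncc1Nc1ccccc1C` gives 1200 nM, a lower number that lies beyond the scatter. Compound 4 `c1ccc(Nc2nc(-c3nc4ccccc4s3)cs2)nc1` is not yet measured in this assay. It differs from compound 3 by pyridin-2-yl in place of phenyl on a nitrogen on an aromatic ring. Within the data shown here, no measured pair shows this change, so no step size is known from the data. Compound 1 carries the same (pyridin-2-yl)amino group on a different core and gives 4800 nM, within the scatter of compound 3. The step of a 1.2-fold lower number from compound 3 to compound 4 (0.09 log units; within the scatter) is therefore expected to be none beyond the scatter. Compound 4 is expected to give 4500 nM, within a range from 1500 nM to 13000 nM.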

Compound 4, half-maximal inhibitory concentration: 6700 nM
Beside the measured number, compound 4's estimate is 1.5-fold (0.17 log units) below it, and the stated range covers the measured number.
By their numbers in this assay, from the lowest: compound 2; then compounds 1, 3 and 4 (each within the scatter of the next).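

In this assay, among these compounds, pyridin-2-yl in place of phenyl on the nitrogen gives a 1.2-fold higher number from compound 3 to compound 4 (0.09 log units; within the scatter) and so provides the first direct reading of this change. At this position, on this one core, the ring nitrogen leaves the number within the scatter. Nothing available explains the size of this step.

Still open, as far as these compounds go, is whether a larger change on this nitrogen, such as a piperazine or a carboxylic acid on the ring, moves the number beyond the scatter. Also open, from the compounds shown here alone, is whether the same change holds on another core.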